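Amidine series: trifluoromethyl removal, HT-1080 cytotoxicity

The source may hold more compounds than are shown below. What is called first, only, known or untested is meant among the compounds shown, and "the series" means these compounds.

Measured compounds:
- compound 1, `CN1CCN(c2ccc(NC(=N)c3cc4cn[nH]c4cn3)cc2)CC1` — in a functional assay on HT-1080 cells (Homo sapiens) for cytotoxicity, read by MTT assay, with a stated time of 72 h (a lower number here means a stronger inhibitor, a higher number a weaker inhibitor), compound 1 gives 31300 nM
- compound 2, `COc1ccc(Cn2cc3cc(C(=N)Nc4cccc(C(F)(F)F)c4)ncc3n2)cc1` — compound 2 gives 13000 nM
- compound 3, `CN1CCN(c2ccc(NC(=N)c3cc4cn(C)nc4cn3)cc2)CC1` — compound 3 gives 21000 nM

Compound 2 holds the lowest number of the three. The gap to compound 3 is within the usual scatter, so no order between these two can be read; the gap to compound 1 lies beyond the scatter, so compound 1 does sit higher than compound 2.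

Compound 4, `COc1ccc(Cn2cc3cc(C(=N)Nc4ccccc4)ncc3n2)cc1`, is not yet measured in this assay. It differs from compound 2 in one place: hydrogen in place of trifluoromethyl on an aromatic carbon of a six-membered aromatic ring of carbon only, meta to a large group. Among the measured compounds shown here, no pair of measured compounds differs in just this way, so there is no step in this set to lean on. The change is small in count, and the expectation is a step from compound 2 to compound 4 of a 1.5-fold higher number from compound 2 to compound 4 (0.19 log units; within the scatter), toward a somewhat higher number, but not clearly beyond the scatter. Compound 4 is therefore estimated at 20000 nM, with a range from 8000 nM to 60000 nM.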

Compound 4, half-maximal inhibitory concentration: 1130 nM
Compound 4: middle estimate off by 18-fold (1.25 log units), on the high side, and the stated range ends above it.
By their numbers in this assay, from the lowest: compound 4; then compounds 2, 3 and 1 (each within the scatter of the next, the first and the last beyond it).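

In this assay, among the compounds shown here, going from 3-(trifluoromethyl)phenyl to phenyl gives a 12-fold lower number from compound 2 to compound 4 (1.06 log units; beyond the scatter), the first step that can be read between compounds differing in one place. For the compounds shown here, this aromatic carbon is therefore not a silent position: losing trifluoromethyl, with its 4 heavy atoms and no hydrogen-bond donor, acceptor or net charge, is enough to produce a large step, which the earlier compounds could not reveal. Nothing available bears on the reason for a step of this size.

As far as these compounds go, it remains open whether the step is specific to trifluoromethyl or would also follow from a methyl group, a chlorine atom or an amine at this carbon. From the compounds shown here alone, it is also open whether the same removal would give a similar step in compounds carrying no methoxybenzyl group, such as compound 1.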